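A few compounds are considered here, and "the series" means these few. Any claim that something is new, unique, unknown or untested is made for them only; others in the source may bear on it.

Series notes. Compound 1 `Cc1ccccc1COc1cc(NC(=O)C2CCCCC2)ccc1N(C)S(C)(=O)=O` serves as the reference; in a functional assay on cells (Homo sapiens) for cytotoxicity, read by MTT assay, with a stated time of 72 h (a lower number here means a stronger inhibitor, a higher number a weaker inhibitor), compound 1 gives 28500 nM. Compound 2 `Cc1ccccc1COc1cc(NC(=O)c2ccccc2)ccc1N(C)S(C)(=O)=O` differs from compound 1 by phenyl in place of cyclohexyl on a carbonyl carbon. In this assay compound 2 gives 176000 nM, a step of a 6.2-fold higher number from compound 1 to compound 2 (0.79 log units; beyond the scatter). Compound 3 `CCCCCCOc1cc(NC(=O)C2CCCCC2)ccc1N(C)S(C)(=O)=O` carries a different core, and the difference from compound 1 is pentyl in place of 2-methylphenyl on a saturated chain carbon bound to an oxygen on an aromatic ring. In this assay compound 3 gives 6980 nM, which amounts to a 4.1-fold lower number from compound 1 to compound 3 (0.61 log units; beyond the scatter) and is the lowest number among the three measured compounds, with compound 2 standing furthest from it.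

Compound 4 `CCCCCCOc1cc(NC(=O)c2ccccc2)ccc1N(C)S(C)(=O)=O` has not yet been measured. It differs from compound 3 by phenyl in place of cyclohexyl on a carbonyl carbon, the same change that separates compound 1 from compound 2, since the place is described in identical words for both pairs; the change occurs twice across the four compounds. Going by the values given here, only one measured instance of it exists, so any expectation rests on that single step and on the assumption that the core of compound 3 does not alter its direction.

Among the compounds with values here, for compound 4 the step from its parent is expected to be about a 6.2-fold higher number from compound 3 to compound 4 (0.79 log units; beyond the scatter), set beside the earlier step because a 6.2-fold higher number from compound 1 to compound 2 (0.79 log units; beyond the scatter) is the only available guide. Compound 4 is therefore expected to give 43000 nM in this assay, with an estimated range from 15000 nM to 130000 nM.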

Compound 4, half-maximal inhibitory concentration: 12000 nM
Compound 4: middle estimate off by 3.6-fold (0.55 log units), on the high side; the whole stated range lies above it.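

Replacing cyclohexyl with phenyl on a carbonyl carbon gives, in this assay, a 1.7-fold higher number from compound 3 to compound 4 (0.24 log units; within the scatter), so the clear penalty seen with this change on the core of compound 1 does not carry over at that size: the same change on two cores in this assay, a 6.2-fold higher number (0.79 log units; beyond the scatter) from compound 1 to compound 2 and a 1.7-fold higher number (0.24 log units; within the scatter) from compound 3 to compound 4, 3.6-fold (0.56 log units) apart, beyond the scatter of two such steps. Read the other way round, the same four compounds show pentyl in place of 2-methylphenyl on a saturated chain carbon bound to an oxygen on an aromatic ring giving a 15-fold lower number from compound 2 to compound 4 (1.17 log units; beyond the scatter), a larger step than on the cyclohexyl amides: the same change on two cores in this assay, a 4.1-fold lower number (0.61 log units; beyond the scatter) from compound 1 to compound 3 and a 15-fold lower number (1.17 log units; beyond the scatter) from compound 2 to compound 4, 3.6-fold (0.56 log units) apart, beyond the scatter of two such steps. The two changes are therefore not additive here and the size of each step depends on the group at the other place, but this is a single set of four compounds seen from two sides, so it gives no reason for the dependence and no rule for any other core.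

Open, as far as these compounds go, is whether a longer chain in place of pentyl would keep the phenyl step as small as it is here, or whether it would return to the size seen with 2-methylphenyl. Also open, from the compounds shown here alone, is how an acetyl group or a benzoyl group carrying a carboxylic acid would behave on each of the two cores.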